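Trimethylphenyl thioether on the indole core

The compounds below may be only part of what the source reports. "The series", "measured", "known", "first", "only" and "open" are said of these compounds alone.

Measured compounds:
compound 1 `CCOC(=O)c1c(CSc2ccccc2OC)n(C)c2ccc(O)cc12` – 2900 nM
compound 2 `CCOC(=O)c1c(CSc2cc(C)cc(C)c2)n(C)c2ccc(O)cc12` – 1800 nM

In an assay for inhibition of Polyunsaturated fatty acid 5-lipoxygenase (Homo sapiens), read by HPLC, with a stated time of 10 min (on this read-out higher numbers stand for weaker inhibition and lower numbers for stronger inhibition), compound 2 has the lower of the two numbers, with compound 1 the nearest at a 1.6-fold lower number from compound 1 to compound 2 (0.21 log units; within the scatter). Compound 3 `CCOC(=O)c1c(CSc2c(C)cc(C)cc2C)n(C)c2ccc(O)cc12` differs from compound 2 by 2,4,6-trimethylphenyl in place of 3,5-dimethylphenyl on a sulfur. Among the compounds with values here, the only measured step concerns a different change on the same sulfur and was itself within the scatter, so it offers no guide to a shift in this assay. Compound 3 is therefore expected to land at about 1800 nM, within 700 nM to 4500 nM, a step of no change at the digits printed from compound 2 to compound 3 (within the scatter) estimated to stay inside the scatter.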

Compound 3, half-maximal inhibitory concentration: 700 nM
The estimate for compound 3 lay 2.6-fold (0.41 log units) above the measured number; the measured number falls inside the stated range.
By their numbers in this assay, from the lowest: compound 3; then compounds 2 and 1 (each within the scatter of the next).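

On the sulfur of the shared core, 2,4,6-trimethylphenyl gives a 2.6-fold lower number from compound 2 to compound 3 (0.41 log units; beyond the scatter) in this assay and also a 4.1-fold lower number from compound 1 to compound 3 (0.62 log units; beyond the scatter) on the same read-out. The aryl group at this place can therefore shift the number beyond the scatter, which the step between compound 1 and compound 2 did not show. Nothing available accounts for this shift.

The compounds shown leave open whether an aryl group carrying an amine or a carboxylic acid on this sulfur would keep the lower number of compound 3.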